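Quinazoline-thioacetamide series: aryl swap on the ring amine

The source may report more compounds than this note shows. Statements on the series, on what has been measured and on what is new or still open speak of the compounds shown alone.

Measured so far in a functional assay on PC-3 cells (Homo sapiens) for inhibition, read by MTT assay, with a stated time of 72 h; on this read-out lower numbers stand for stronger inhibition and higher numbers for weaker inhibition:
- compound 1 `O=C(CSc1nc(Nc2ccccc2)c2ccccc2n1)Nc1ccccc1Cl` gives 14600 nM
- compound 2 `O=C(CSc1nc(Nc2ccccc2)c2ccccc2n1)Nc1ccc(Br)cc1` gives 8450 nM
- compound 3 `C=CC(=O)Nc1cccc(NC(=O)CSc2nc(Nc3ccccc3Br)c3ccccc3n2)c1` gives 17100 nM

Compound 3 sits at the high end of the three numbers: compared with compound 2 its number is larger by a margin beyond the scatter, whereas the gap between compound 3 and compound 1 is within the scatter, so no order between those two is claimed.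

Compound 4 `C=CC(=O)Nc1cccc(NC(=O)CSc2nc(Nc3ccc(Cl)cc3Cl)c3ccccc3n2)c1` differs from compound 3 in one place: 2,4-dichlorophenyl in place of 2-bromophenyl on a nitrogen on an aromatic ring. For the measured compounds named here, the single measured step, a 1.7-fold lower number from compound 1 to compound 2 (0.24 log units; within the scatter), concerns the aryl on the amide-type nitrogen, not the aryl on the nitrogen on the aromatic ring, so it bears only loosely on this change; it shows that exchanging one halogenated phenyl for another there stayed within the scatter. Going by the values given here, no measured pair speaks directly to the (2-bromophenyl)amino to (2,4-dichlorophenyl)amino exchange. The expectation for compound 4 in this assay is therefore no step beyond the scatter, a 1.1-fold lower number from compound 3 to compound 4 (0.06 log units; within the scatter), with wide uncertainty. Compound 4 is estimated at 15000 nM, in the range 5000 nM to 45000 nM.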

Compound 4, half-maximal inhibitory concentration: 25700 nM
Beside the measured number, compound 4's estimate is 1.7-fold (0.23 log units) below it; the measured number falls inside the stated range.
By their numbers in this assay, from the lowest: compounds 2, 1, 3 and 4 (each within the scatter of the next, the first and the last beyond it).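

At the nitrogen on an aromatic ring, exchanging 2-bromophenyl for 2,4-dichlorophenyl reads in this assay as a 1.5-fold higher number from compound 3 to compound 4 (0.18 log units; within the scatter), and this is the only pair shown that varies this position. The exchange adds a second halogen-bearing aryl to this nitrogen without a step beyond the scatter, so no order between these two compounds is claimed. No measured data bear on this result, and the step stays without explanation.

Still open, going by these compounds, is whether a methoxy group, an amine or a carboxylic acid on this phenyl ring, or a longer chain in place of the aryl on this nitrogen, would move the number beyond the scatter. For the compounds shown here, the contribution of the acrylamide also remains open: compound 3 differs from compound 1 in more than one place, and no single-place pair isolates that group.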